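Removing the benzyloxy group from compound 1

A few compounds are considered here, and "the series" means these few. Any claim that something is new, unique, unknown or untested is made for them only; others in the source may bear on it.

Measured so far:
compound 1, `O=[N+]([O-])c1cc(OCc2ccccc2)ccc1CNc1cc(C(F)(F)F)cc2[nH]ncc12`, 49%
compound 2, `O=C1NCc2c(NCc3ccccc3[N+](=O)[O-])cccc21`, 23%
compound 3, `O=C(O)c1cccc(CNc2cc(C(F)(F)F)cc3[nH]ncc23)c1`, 81%

In an assay for inhibition of Tryptophan 2,3-dioxygenase (Homo sapiens), with stated times of 10 min and 60 min, tested at 10 uM (a lower number here means a weaker effect, a higher number a stronger effect of the compound at the concentration tested), compound 1 gives 49%, the second highest of the three numbers. Its nearest neighbour is compound 2, whose value lies lower by a gap beyond the scatter, and the furthest is compound 3, whose value lies higher by a gap also beyond the scatter. No pair among these three differs in only one place, so no single step is known here.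

Compound 4, `O=[N+]([O-])c1ccccc1CNc1cc(C(F)(F)F)cc2[nH]ncc12`, has not yet been measured. It differs from compound 1 as follows: hydrogen in place of benzyloxy on an aromatic carbon. The three measured compounds give no direct guide to what the loss of this group does, since none of them share the core of compound 1 apart from compound 3, which carries a different substituent pattern altogether.

The step of a number 16 percentage points lower from compound 1 to compound 4 (beyond the scatter) is expected to be a moderate fall, beyond the scatter, on the reasoning that compound 1 gives 49% with the larger substituent in place. Compound 4 is therefore estimated at 33%, within a range from 12% to 58%.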

Compound 4, a percentage reported as inhibition, at one concentration (the size of the read-out at that concentration, not a potency): 89%
For compound 4 the middle estimate is 56 percentage points below the measured one; the measured number lies above the stated range.
By their numbers in this assay, from the lowest: compound 2; then compound 1; then compounds 3 and 4 (each within the scatter of the next).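

Replacing benzyloxy with hydrogen on this aromatic carbon, meta to a nitro group and para to a large group, gives in this assay a large step, a number 40 percentage points higher from compound 1 to compound 4 (beyond the scatter), so the benzyloxy group is not needed for the effect at the concentration tested. This is the first change in one place among the compounds shown, and it shows that the larger substituent goes with the lower number on this core. No measurement shown accounts for this rise.

From the compounds shown here alone, it remains open whether a smaller group at this carbon, such as methoxy or a single fluorine atom, would keep the number of compound 4 or move it towards that of compound 1. A longer chain or an amine at the same carbon is equally untested by the compounds shown, and a read-out at one concentration gives no potency for either compound.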